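A few compounds are considered here, and "the series" means these few. Any claim that something is new, unique, unknown or untested is made for them only; others in the source may bear on it.

Measured so far:
compound 1 `COc1ccc(SC)c(NCC2=NCCN2)c1` — 5.01 nM
compound 2 `CS(=O)(=O)c1ccc(Cl)cc1NCC1=NCCN1` — < 100000 nM

Of the compounds shown here, two have been tested in a functional assay for agonist activity at Alpha-1D adrenergic receptor (Homo sapiens); a lower number here means that less compound is needed, a higher number that more compound is needed for the effect. Compound 1 has the structure `COc1ccc(SC)c(NCC2=NCCN2)c1` and gives 5.01 nM. Compound 2 has the structure `CS(=O)(=O)c1ccc(Cl)cc1NCC1=NCCN1`; for compound 2 the assay reports only a limit, < 100000 nM, so where it truly stands on the scale is not known, and this is seen in the limit of < 100000 nM in this assay, at which 1 of the 2 values shown sits. Compound 3, with the structure `CSc1ccc(Cl)cc1NCC1=NCCN1`, has not yet been measured. It differs from compound 2 in one place: methylsulfanyl in place of methylsulfonyl on an aromatic carbon. Because compound 2 is known only as a limit, the step from compound 2 to compound 3 cannot be given a size from measured numbers; the expectation is that compound 3 will need noticeably less compound, and the estimate means a step that the limit leaves unreadable from compound 2 to compound 3. For compound 3 the expected value in this assay is 15 nM, with a likely range from 2 nM to 150 nM.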

Compound 3, half-maximal effective concentration: 2.69 nM
For compound 3 the middle estimate is 5.6-fold (0.75 log units) above the measured one, and the stated range covers the measured number.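

In this assay, compound 3 shows that a chloro-bearing compound with methylsulfanyl on this aromatic carbon, para to the chloro group, gives a low number, which compound 2 alone could not show. The size of the change from methylsulfonyl to methylsulfanyl cannot be read, because compound 2 is known only as a limit: the limit of < 100000 nM in this assay, at which 1 of the 3 values shown sits. Chloro in place of methoxy on the other aromatic carbon gives a 1.9-fold lower number from compound 1 to compound 3 (0.27 log units; within the scatter), so with methylsulfanyl present the two compounds cannot be told apart here.

The compounds shown leave open how an amine, a methoxy group or a longer chain such as ethylsulfanyl would behave in place of methylsulfanyl. They also leave open whether a sulfur atom is needed at this place at all.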